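Removing a methoxy from the benzyl group of compound 2

A few compounds are considered here, and "the series" means these few. Any claim that something is new, unique, unknown or untested is made for them only; others in the source may bear on it.

In a functional assay on RAW264.7 cells (Mus musculus) for inhibition, with stated times of 2 h and 24 h (a lower number here means a stronger inhibitor, a higher number a weaker inhibitor), compound 1 (`COc1ccc(/C=C2/c3cc(OC)cc(OC)c3[C@@H](c3ccc(OC)cc3)[C@@H]2c2cc(OC)cc(OC)c2)cc1`) gives 6260 nM and compound 2 (`COc1ccc(CSC2c3cc(OC)cc(OC)c3[C@@H](c3ccc(OC)cc3)[C@@H]2c2cc(OC)cc(OC)c2)cc1`) gives 12500 nM, two values within the usual scatter of each other. Compound 3 (`COc1ccc(CSC2c3cc(OC)cc(OC)c3[C@@H](c3ccccc3)[C@@H]2c2cc(OC)cc(OC)c2)cc1`) reads > 200000 nM, and this entry is a limit of the assay and not a number.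

Compound 4 (`COc1ccc([C@@H]2c3c(OC)cc(OC)cc3C(SCc3ccccc3)[C@H]2c2cc(OC)cc(OC)c2)cc1`) is compound 2 with a single change: hydrogen in place of methoxy on an aromatic carbon. Hydrogen takes the place of methoxy on an aromatic carbon, para to a large group, so 4-methoxybenzyl becomes benzyl.

For the measured compounds named here, only one measured step bears on this. The same swap, described in words, gave an at least 16-fold higher number from compound 2 to compound 3 (1.20 log units; beyond the scatter), a large step beyond the scatter. However, it happened elsewhere on the molecule: compound 3 loses the methoxy of the 4-methoxyphenyl group and keeps the 4-methoxybenzyl group, the very group that changes in compound 4. That step therefore offers a hint about direction but little guidance on size.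

A much smaller rise in the same direction is expected, namely a 2.4-fold higher number from compound 2 to compound 4 (0.38 log units; beyond the scatter), in this assay. For compound 4 the estimated value is 30000 nM, with an expected range from 9000 nM to 120000 nM.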

Compound 4, half-maximal inhibitory concentration: > 200000 nM
Compound 4 ended at the assay's limit (the forecaster's own chance of this, stated with the estimate: 15%); middle value at least 6.6-fold (0.82 log units) away from the limit.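

In this assay, the methoxy of the 4-methoxybenzyl group turns out to matter in its own right: replacing it with hydrogen gives an at least 16-fold higher number from compound 2 to compound 4 (1.20 log units; beyond the scatter). Compound 3 could not show this, as it keeps that group and loses a methoxy elsewhere, so the result adds a second place on compound 2 where this same swap costs much of the activity. Compound 4 reads > 200000 nM, which is a limit of the assay and not a number. The two steps, an at least 16-fold higher number from compound 2 to compound 3 (1.20 log units; beyond the scatter) and the one to compound 4, therefore give only minimum sizes and cannot be ranked against each other: the limit of > 200000 nM in this assay, at which 2 of the 4 values shown sit.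

As far as these compounds go, what would happen with something other than hydrogen in this place stays open, whether a hydroxyl, a fluorine, an amine or a longer chain such as ethoxy, and so does how much of the activity of compound 2 any of these would keep. From the compounds shown here alone, it is also open whether compound 1, which carries no sulfur, would respond to the loss of its corresponding methoxy in the same way.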